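The source may report more compounds than this note shows. Statements on the series, on what has been measured and on what is new or still open speak of the compounds shown alone.

Measured compounds in a functional assay on Hep 3B2 cells (Homo sapiens) for antiproliferative activity, read by MTT assay, with a stated time of 24 h, tested at 0.05 ug/mL; on this read-out higher numbers stand for a stronger effect at the one concentration tested and lower numbers for a weaker effect:
compound 1 `COc1ccc2nc(C(=O)Nc3ccc(-c4ccccc4)cc3)c(C)c(O)c2c1` gives 1.23%
compound 2 `Cc1c(C(=O)Nc2ccc(-c3ccccc3)cc2)nc2ccccc2c1O` gives 1.68%
compound 3 `CCc1ccc2nc(C(=O)Nc3c(F)cc(-c4cccc(F)c4)cc3F)c(C)c(C(=O)O)c2c1` gives 0%

Compound 2 holds the highest of the three numbers, but its nearest neighbour, compound 1, lies only slightly lower (a number 0.5 percentage points higher from compound 1 to compound 2 (within the scatter)), and compound 3 lies further down by a gap that is also within the scatter. All three numbers are, in effect, indistinguishable from one another and from no effect in this assay.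

Compound 4 `Cc1c(C(=O)Nc2ccc(-c3ccccc3)cc2)nc2ccccc2c1C(=O)O` is the next member to be measured. It differs from compound 2 in one place: carboxy in place of hydroxy on an aromatic carbon.

Among the compounds with values here, no measured step bears directly on this change. Within the data shown here, the one single-place step in hand, a number 0.5 percentage points higher from compound 1 to compound 2 (within the scatter), concerns a different position and is within the scatter. Compound 3 carries a carboxy group but differs from compound 2 in several places at once, so only its bare value can be set beside that of compound 2, and the two numbers are within the scatter of each other. Nothing in the measured set points to a step beyond the scatter in this assay for the change from hydroxy to carboxy; the expected step is a number 0.7 percentage points lower from compound 2 to compound 4 (within the scatter).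

Compound 4 is therefore estimated at 1%, with a range from 0% to 8%.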

Compound 4, a percentage reported as inhibition, at one concentration (the size of the read-out at that concentration, not a potency): -0.12%
For compound 4 the middle estimate is 1.1 percentage points above the measured one; measured number outside the range, below it.
By their numbers in this assay, from the lowest: compounds 4, 3, 1 and 2 (each within the scatter of the next).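

In this assay, the exchange of hydroxy for carboxy on the aromatic carbon opposite the ring nitrogen now has a single-place reading: a number 1.8 percentage points lower from compound 2 to compound 4 (within the scatter). Compound 3 also carries carboxy, but together with differences in several other places, whereas this pair isolates the exchange on an otherwise shared structure and shows that, at the one concentration tested, it produces no step beyond the scatter, with compound 2 at 1.68% and compound 4 at -0.12%. No measured information bears on the reason for this result.

From the compounds shown here alone, with all the numbers lying within the scatter of their neighbours and close to no effect, this reading cannot show whether the position matters for activity, so it remains open whether an amine, a methyl ester or a primary carboxamide on the same carbon would give a step beyond the scatter. Also open, going by these compounds, is whether the exchange of hydroxy for carboxy would read the same at a higher concentration, where the read-out might rise clear of the scatter, or on the methoxy-bearing core of compound 1.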